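The source may report more compounds than this note shows. Statements on the series, on what has been measured and on what is new or still open speak of the compounds shown alone.

Measured in a physicochemical assay for solubility, read by spectrophotometry, measured as kinetic solubility, at pH 8, tested at 500 uM; on this read-out lower numbers stand for lower solubility and higher numbers for higher solubility:
- compound 1 `Cn1ccc2ccc(-c3cc(Nc4cnccc4C(=O)NC4CCNC(=O)C4)cc4nccnc34)cc21`: 242 ug/mL
- compound 2 `CC(=O)N1CC(CNC(=O)c2ccncc2Nc2cc(-c3ccc4ccn(C)c4c3)c3nccnc3c2)C1`: 252 ug/mL

Within the data shown here, these two values lie within the scatter of each other, so compound 2 stands level with the only other measured compound. Compound 3 `CN1CCC(CNC(=O)c2ccncc2Nc2cc(-c3ccc4ccn(C)c4c3)c3nccnc3c2)C1` has not yet been measured. It differs from compound 2 in one place: 1-methylpyrrolidin-3-yl in place of 1-acetylazetidin-3-yl on a saturated chain carbon bound to an amide-type nitrogen. In words, 1-methylpyrrolidin-3-yl stands in place of 1-acetylazetidin-3-yl on a saturated chain carbon bound to an amide-type nitrogen.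

Among the measured compounds shown here, no measured step covers this exchange itself. For the measured compounds named here, the one step that bears on it is a 1.0-fold higher number from compound 1 to compound 2 (0.02 log units; within the scatter), which also changed the group on the amide-type nitrogen. On that single step, no change beyond the scatter is expected in this assay, and no direction can be claimed. The estimated step is a 1.1-fold lower number from compound 2 to compound 3 (0.03 log units; within the scatter). Compound 3 is expected at 235 ug/mL, with an estimated range from 140 ug/mL to 280 ug/mL.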

Compound 3, solubility: 246 ug/mL
Beside the measured number, compound 3's estimate is 1.0-fold (0.02 log units) below it; measured number inside the range.
By their numbers in this assay, from the lowest: compounds 1, 3 and 2 (each within the scatter of the next).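

In this assay, the exchange of 1-acetylazetidin-3-yl for 1-methylpyrrolidin-3-yl on a saturated chain carbon bound to an amide-type nitrogen gives a 1.0-fold lower number from compound 2 to compound 3 (0.01 log units; within the scatter), so a five-membered ring bearing methyl stands level with a four-membered ring bearing acetyl. The comparison with the 2-oxopiperidin-4-yl group gives a 1.0-fold higher number from compound 1 to compound 3 (0.01 log units; within the scatter), so all three groups shown on this amide-type nitrogen now stand level in this read-out. Nothing measured here gives a reason for this flatness.

On these data alone, whether a carboxylic acid or a longer chain in this place would carry the number beyond the scatter remains open. So does whether this flatness would hold with a different group on the shared core.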